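This account rests on a few compounds, and the source may have more. Where it says the series, first, only, none or still open, it means among the compounds named here.

Measured so far in a functional assay on the whole organism for inhibition, with Rattus norvegicus as the target, at a dose of 50 mg/kg by the oral route; a higher number here means more inhibition at the dose given (going by the name of the read-out), a lower number less inhibition:

Compound 1, `CCOC(=O)c1c(CSc2nccn2C)nc2cc(OC)c(OC)cc2c1-c1ccc(OC)c(OC)c1`: 60%
Compound 2, `CCOC(=O)c1c(CSc2nccn2C)nc2cc(OC)c(OC)cc2c1-c1ccc(C)cc1`: 67%

Compound 2 stands highest of the two numbers shown, but its only neighbour is compound 1, and the step of a number 7 percentage points higher from compound 1 to compound 2 (within the scatter) lies within the scatter, so the two compounds cannot be placed in any order on these data.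

Compound 3, `CCOC(=O)c1c(CSc2nccn2C)nc2cc(OC)c(OC)cc2c1-c1ccc(Cl)cc1`, differs from compound 2 in one place: chloro in place of methyl on an aromatic carbon. Within the data shown here, the one measured step, a number 7 percentage points higher from compound 1 to compound 2 (within the scatter), exchanged the whole ring at this position, from 3,4-dimethoxyphenyl to 4-methylphenyl, and stayed within the scatter. Among the measured compounds shown here, no measured step concerns chloro in place of methyl itself, so the expectation for compound 3 rests on that single step and on the size of the exchange, one heavy atom for one heavy atom. Nothing in the data points to a shift beyond the scatter in either direction, and the expected step of a number 2 percentage points lower from compound 2 to compound 3 (within the scatter) is therefore read as no real change.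

The estimate for compound 3 in this assay is 65%, with a range from 45% to 82%.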

Compound 3, a percentage reported as inhibition, in the whole organism at one dose (the size of the read-out at that dose, not a potency): 41%
Beside the measured number, compound 3's estimate is 24 percentage points above it; measured number below the stated range.
By their numbers in this assay, from the lowest: compound 3; then compounds 1 and 2 (each within the scatter of the next).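

In this assay, among these compounds, the group para to a large group on this ring can matter: one heavy atom exchanged for another, chloro in place of methyl, gives a number 26 percentage points lower from compound 2 to compound 3 (beyond the scatter) and is the first step here that can be read. The 4-chlorophenyl group also compares poorly with the much larger 3,4-dimethoxyphenyl group, with a number 19 percentage points lower from compound 1 to compound 3 (beyond the scatter) on the same shared core, so a small exchange at this place can matter more than replacing the ring's substituents wholesale. Methyl and chloro match in heavy atoms and in hydrogen-bond donors and acceptors, so those counts do not separate them, and no measurement at hand gives a reason for the gap.

Three compounds cannot show whether the lower number belongs to chloro alone or to a wider set of groups at this place. Plain hydrogen, fluoro, an ethyl chain, an amine or a carboxylic acid in place of methyl would each test this, and a chloro moved elsewhere on the ring would show whether the place itself counts as much as the group.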